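A few compounds are considered here, and "the series" means these few. Any claim that something is new, unique, unknown or untested is made for them only; others in the source may bear on it.

Compound 1 `O=C(O)c1ccc(C(=O)/C(=C\c2ccc(F)c([N+](=O)[O-])c2)S(=O)(=O)Cc2ccc(Br)cc2)cc1`: < 1000 ug/mL, a limit of the assay.
Compound 2 `O=C(O)c1ccc(C(=O)/C(=C\c2ccc(F)cc2[N+](=O)[O-])SCc2ccc(Br)cc2)cc1`: < 1000 ug/mL, a limit of the assay.
Compound 3 `O=C(O)c1ccc(C(=O)/C(=C\c2ccc(Cl)c([N+](=O)[O-])c2)SCc2ccc(Cl)cc2Cl)cc1`: < 1000 ug/mL, a limit of the assay.

In a physicochemical assay for solubility (a lower number here means a less soluble compound, a higher number a more soluble compound), compound 1 gives < 1000 ug/mL, which is a limit of the assay rather than a measured number. The other two values show the same picture: the limit of < 1000 ug/mL in this assay, at which 3 of the 3 values shown sit. Compound 4 `O=C(O)c1ccc(C(=O)/C(=C\c2ccc(F)c([N+](=O)[O-])c2)SCc2ccccc2Cl)cc1` has not yet been measured in this assay. It differs from compound 1 in one place: (2-chlorobenzyl)sulfanyl in place of (4-bromobenzyl)sulfonyl on a double-bonded chain carbon bound to a carbonyl carbon and a double-bonded chain carbon. For the measured compounds named here, since no step between measured compounds is known, the values give no direction to read from. Compound 4 is therefore expected to sit at the same limit, an expected step that the limit leaves unreadable from compound 1 to compound 4 in this assay. Compound 4 is estimated at 200 ug/mL, with a range from 20 ug/mL to 1000 ug/mL.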

Compound 4, solubility: < 1000 ug/mL
Compound 4: no number, only a limit; the forecaster's own chance of this, stated with the estimate: 85%; the middle value is on the limit's open side.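

No step can be read from compound 1 to compound 4 in this assay, since both values are limits rather than numbers: the limit of < 1000 ug/mL in this assay, at which 4 of the 4 values shown sit.

What (2-chlorobenzyl)sulfanyl in place of (4-bromobenzyl)sulfonyl does in this assay stays open, as does the actual value of each compound shown.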